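Replacing the Hydroxy of Compound 1 with an Aminoethylamide

A few compounds are considered here, and "the series" means these few. Any claim that something is new, unique, unknown or untested is made for them only; others in the source may bear on it.

Compound 1 `O=C(O)CCC(=O)OCCCCCCSc1ccc([N+](=O)[O-])c2nonc12` ends its chain in a free carboxy group. In an assay on isolated protein for inhibition of glutathione S-transferase P (Homo sapiens), with a stated time of 10 min (on this read-out higher numbers stand for weaker inhibition and lower numbers for stronger inhibition), compound 1 gives 530 nM, the lowest of the two numbers available. Compound 2 `O=C(CCC(=O)OCCCCCCSc1ccc([N+](=O)[O-])c2nonc12)Nc1ccc(C(F)(F)F)cc1` carries (4-(trifluoromethyl)phenyl)amino in place of that hydroxy on the carbonyl carbon, and in this assay compound 2 gives 5050 nM. The step between them is a 9.5-fold higher number from compound 1 to compound 2 (0.98 log units; beyond the scatter). Compound 3 `CN(C)CCNC(=O)CCC(=O)OCCCCCCSc1ccc([N+](=O)[O-])c2nonc12` has not yet been measured; it differs from compound 1 as follows: (2-(dimethylamino)ethyl)amino in place of hydroxy on a carbonyl carbon. Among the measured compounds shown here, the only measured step that bears on this change is the conversion of the acid of compound 1 into the amide of compound 2, which raised the number beyond the scatter. A higher number is therefore expected for compound 3 as well, though with a different entering group the step is expected to be more moderate: a 3.8-fold higher number from compound 1 to compound 3 (0.58 log units; beyond the scatter). Compound 3 is estimated to give 2000 nM in this assay, within a range from 700 nM to 6000 nM.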

Compound 3, half-maximal inhibitory concentration: 540 nM
For compound 3 the middle estimate is 3.7-fold (0.57 log units) above the measured one; measured number below the stated range.
By their numbers in this assay, from the lowest: compounds 1 and 3 (each within the scatter of the next); then compound 2.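

In this assay the acid and this amide are not separated (a 1.0-fold higher number from compound 1 to compound 3 (0.01 log units; within the scatter)), so the carboxy group on this carbonyl carbon can be exchanged for (2-(dimethylamino)ethyl)carbamoyl without a difference the read-out resolves. The amide link alone therefore does not go with a higher number; what sits on the amide nitrogen matters, as the exchange of 4-(trifluoromethyl)phenyl for 2-(dimethylamino)ethyl shows (a 9.4-fold lower number from compound 2 to compound 3 (0.97 log units; beyond the scatter)). Nothing given here accounts for this result.

On these data alone, with only two amides at this position, it remains open how a plain phenyl, without trifluoromethyl, would read on the amide nitrogen. As far as these compounds go, it is equally open whether a longer chain leading to the dimethylamino group, or a primary amine in its place, would keep the number of compound 3.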